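Phenyl to Cyclopropyl on the Amine of Compound 1

The source may hold more compounds than are shown below. What is called first, only, known or untested is meant among the compounds shown, and "the series" means these compounds.

Compound 1 `CC(=O)NC[C@H]1CN(c2ccc(OC[C@@H](O)CNc3ccccc3)c(F)c2)C(=O)O1`: 1.42
Compound 2 `CC(=O)NC[C@H]1CN(c2ccc(OC[C@H](O)CNc3ccncc3)c(F)c2)C(=O)O1`: 0.02

Of the compounds shown here, two have been measured in a physicochemical assay for lipophilicity, read by HPLC (a lower number here means a more polar compound, a higher number a more lipophilic compound), and compound 1 stands highest of the two, with compound 2 the nearest at a number 1.40 log units lower from compound 1 to compound 2 (beyond the scatter). That single step exchanges 2-anilino-1-hydroxyethyl for 1-hydroxy-2-((pyridin-4-yl)amino)ethyl on a saturated chain carbon bound to an oxygen on an aromatic ring, and it moved the number a long way down.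

Compound 3 `CC(=O)NC[C@H]1CN(c2ccc(OC[C@@H](O)CNC3CC3)c(F)c2)C(=O)O1` has not been measured. It differs from compound 1 in one place: cyclopropyl in place of phenyl on an amine nitrogen. For the measured compounds named here, no measured pair carries exactly this exchange, so the only guide is the step from compound 1 to compound 2, in which the phenyl on that same amine nitrogen was also replaced and the number fell by a large margin. On that basis the step from compound 1 to compound 3 is expected to run downward, beyond the scatter, by about a number 1.82 log units lower from compound 1 to compound 3 (beyond the scatter). Compound 3 is therefore estimated at -0.4, with a range from -1.2 to 0.4.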

Compound 3, partition coefficient: 0.02
Compound 3: the middle estimate sits 0.42 log units below what was measured; the range from low to high includes it.
By their numbers in this assay, from the lowest: compounds 2 and 3 (each within the scatter of the next); then compound 1.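

In this assay, the phenyl on the amine nitrogen of compound 1 now has a second replacement: cyclopropyl gives a number 1.40 log units lower from compound 1 to compound 3 (beyond the scatter), so a large downward step on this nitrogen is not confined to the pyridin-4-yl exchange. The two replacements cannot be told apart, with no change at the digits printed from compound 2 to compound 3 (within the scatter), although one brings a three-membered non-aromatic ring of carbon only and the other a pyridine, which is something the earlier pair alone could not show. Nothing available explains either the size of the drop from phenyl or the match between the two replacing groups.

The compounds shown leave open how the number depends on the group on this amine nitrogen, since only phenyl, pyridin-4-yl and cyclopropyl are compared there. A cyclohexyl or a methyl on the same nitrogen would show whether the reading follows the number of carbons in the group, or whether a saturated ring larger than cyclopropyl comes closer to the phenyl of compound 1.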